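Methyl to Methoxy in a Series Sitting at the Limit

The source may report more compounds than this note shows. Statements on the series, on what has been measured and on what is new or still open speak of the compounds shown alone.

Compound 1 `Cc1ccccc1S(=O)(=O)Nc1ccc2oc(-c3ccccc3)nc2c1` carries a sulfonamide whose aryl part bears a methyl group. In an assay on isolated protein for inhibition of malate dehydrogenase, mitochondrial (Sus scrofa), with stated times of 45 min and 30 min (on this read-out lower numbers stand for stronger inhibition and higher numbers for weaker inhibition), compound 1 gives > 63000 nM, and this is a limit of the assay rather than a measured number. Compound 2 `O=S(=O)(Nc1ccc(-c2nc3ccccc3o2)cc1)c1ccccc1C(F)(F)F` belongs to the same series. In this assay compound 2 gives > 63000 nM, again a limit. Compound 3 `O=S(=O)(Nc1ccc(-c2nc3ccccc3o2)cc1)c1cccc(O)c1` is a further relative. In this assay compound 3 gives > 63000 nM, also a limit. So every measured compound stops at the same point, (the limit of > 63000 nM in this assay, at which 3 of the 3 values shown sit), and compound 1 stands level with the others, without a number that would set it apart.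

Compound 4 `COc1ccccc1S(=O)(=O)Nc1ccc2oc(-c3ccccc3)nc2c1` differs from compound 1 in one place: methoxy in place of methyl on an aromatic carbon. Among the compounds with values here, no step between two measured compounds is available, so nothing shows how this change acts on the read-out. Because all three measured compounds sit at the limit (the limit of > 63000 nM in this assay, at which 3 of the 3 values shown sit), compound 4 is expected to remain there as well. The expected step, a step that the limit leaves unreadable from compound 1 to compound 4, is none beyond the scatter. Compound 4 is estimated at 100000 nM, in a range from 30000 nM to 400000 nM.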

Compound 4, half-maximal inhibitory concentration: > 63000 nM
Compound 4 was reported as a limit (the forecaster's own chance of this, stated with the estimate: 85%); the middle value does not contradict the limit.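

Compound 1 and compound 4 both stop at a limit of the assay, so no step can be read for methoxy in place of methyl: the limit of > 63000 nM in this assay, at which 4 of the 4 values shown sit.

The compounds shown leave open whether any change to this series would give a measurable number in this assay.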